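The source may hold more compounds than are shown below. What is called first, only, known or untested is meant among the compounds shown, and "the series" means these compounds.

Compound 1 `FC(F)(F)c1ccccc1-c1nc(NCc2ccc(Cl)cc2)c2ccccc2n1`, compound 2 `FC(F)(F)c1ccc(CNc2nc(-c3ccccc3C(F)(F)F)nc3ccccc23)cc1` and compound 3 `FC(F)(F)c1ccccc1-c1nc(NCC#Cc2cccnc2)c2ccccc2n1` were measured in an assay on a protein complex for inhibition of ubiquitin carboxyl-terminal hydrolase 1/WD repeat-containing protein 48 (Homo sapiens), read by fluorescence; on this read-out lower numbers stand for stronger inhibition and higher numbers for weaker inhibition. Compound 1 gives 4800 nM, compound 2 gives 8900 nM and compound 3 gives 8900 nM.

Compound 2 thus stands level with compound 3 at the digits shown, the two together at the top of these three numbers; the steps are a 1.9-fold higher number from compound 1 to compound 2 (0.27 log units; within the scatter), a 1.9-fold higher number from compound 1 to compound 3 (0.27 log units; within the scatter) and no change at the digits printed from compound 2 to compound 3 (within the scatter). Compound 4 `FC(F)(F)c1ccccc1-c1nc(NCc2ccc(-c3ccc(Cl)cc3)cc2)c2ccccc2n1` differs from compound 2 by 4-chlorophenyl in place of trifluoromethyl on an aromatic carbon, para to a large group. For the measured compounds named here, the only measured step on the same aromatic carbon is a 1.9-fold higher number from compound 1 to compound 2 (0.27 log units; within the scatter), and no measured pair exchanges a small group for a ring there. All known steps lie within the scatter, so in this assay no step beyond the scatter is expected. Compound 4 is therefore estimated at 6000 nM, between 1500 nM and 25000 nM, an expected step of a 1.5-fold lower number from compound 2 to compound 4 (0.17 log units; within the scatter).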

Compound 4, half-maximal inhibitory concentration: 3600 nM
Beside the measured number, compound 4's estimate is 1.7-fold (0.22 log units) above it; measured number inside the range.
By their numbers in this assay, from the lowest: compounds 4, 1, 2 and 3 (each within the scatter of the next, the first and the last beyond it).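

For the compounds shown here, the change to 4-chlorophenyl gives a 2.5-fold lower number from compound 2 to compound 4 (0.39 log units; beyond the scatter) in this assay and is the first step here beyond the scatter, so this aromatic carbon accepts an aromatic ring in place of a small group. Set against chloro, the same ring gives a 1.3-fold lower number from compound 1 to compound 4 (0.12 log units; within the scatter) and so stands apart from trifluoromethyl only, not from chloro. From the compounds shown here alone, whether an amine or a carboxylic acid on this carbon would hold this level remains open. No measurement shown accounts for the difference between these groups.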